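The source may report more compounds than this note shows. Statements on the series, on what has been measured and on what is new or still open speak of the compounds shown alone.

In a functional assay on SW1573 cells (Homo sapiens) for antiproliferative activity, read by sulforhodamine B assay, with a stated time of 48 h (a higher number here means a weaker inhibitor of growth, a lower number a stronger inhibitor of growth), compound 1 (`CC(C)(C)[Si](C)(C)O[C@@H]1CCCO[C@@H]1CO`) gives > 100000 nM, which is a limit of the assay and not a number. Within the data shown here, compound 2 (`COC(=O)/C=C/OC[C@H]1OCCC[C@H]1O[Si](C)(C)C(C)(C)C`) gives 50000 nM, the only true number so far. Compound 3 (`CC(C)(C)[Si](C)(C)O[C@@H]1CCCO[C@@H]1CO/C=C/CO`) follows from compound 2 by one change, hydroxymethyl in place of methoxycarbonyl on a double-bonded chain carbon bound to a double-bonded chain carbon.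

Among the measured compounds shown here, only one measured step bears on this, an at least 2.0-fold lower number from compound 1 to compound 2 (0.30 log units; that floor lies within the scatter), in which 2-(methoxycarbonyl)ethenyl took the place of hydrogen on an oxygen on a saturated carbon. As far as these compounds go, that step starts from the limit of > 100000 nM in this assay, at which 1 of the 2 values shown sits, so its true size remains open, and it does not test the methoxycarbonyl group alone. With so small a step from compound 1 to go on, an at least 2.0-fold lower number from compound 1 to compound 2 (0.30 log units; that floor lies within the scatter) gives no ground for expecting a large move in this assay. The expected change, a 1.2-fold higher number from compound 2 to compound 3 (0.08 log units; within the scatter), stays within the usual scatter, though a reading at the limit of the assay remains possible. For compound 3 the estimated value is 60000 nM, with an expected range from 20000 nM to 150000 nM.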

Compound 3, concentration for 50% growth inhibition: > 100000 nM
Compound 3: only a limit was reported (the forecaster's own chance of this, stated with the estimate: 35%); middle value at least 1.6-fold (0.22 log units) from the limit.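

In this assay compound 3 gives > 100000 nM, which is a limit of the assay and not a number. This is the first change shown on the chain itself: on a double-bonded chain carbon bound to a double-bonded chain carbon, hydroxymethyl in place of methoxycarbonyl gives an at least 2.0-fold higher number from compound 2 to compound 3 (0.30 log units; that floor lies within the scatter), so no gain in growth inhibition appears with hydroxymethyl, though the true size of the step stays open. The step from compound 1 to compound 3 cannot be read, and compound 2 remains the only compound with a true number, while the other readings stop at the same ceiling: the limit of > 100000 nM in this assay, at which 2 of the 3 values shown sit.

The compounds shown leave open whether the weak activity of compound 2 depends on methoxycarbonyl itself, or whether a carboxylic acid, a primary amide or a longer chain at this place would read differently. They also leave open how far compound 1 and compound 3 lie from compound 2, and so whether hydroxymethyl changes anything beyond the usual scatter.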